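The source may hold more compounds than are shown below. What is called first, only, known or untested is meant among the compounds shown, and "the series" means these compounds.

Measured in an assay on Prostate gland for inhibition of 3-oxo-5-alpha-steroid 4-dehydrogenase 2 (Rattus norvegicus); a lower number here means a stronger inhibitor, a higher number a weaker inhibitor:

Compound 1, `O=C(O)c1ccc(C=C2CCN(C(=O)C(C3CCCCC3)C3CCCCC3)CC2)cc1`, gives 80 nM.
Compound 2, `O=C(O)c1ccc(C=C2CCN(C(=O)C(c3ccccc3)c3ccccc3)CC2)c(F)c1`, gives 1100 nM.
Compound 3, `O=C(O)c1ccc(C=C2CCN(C(=O)C(C3CCCCC3)C3CCCCC3)CC2)c(F)c1`, gives 3000 nM.

Compound 3 stands at the highest number of the three in this assay, so it is the weakest inhibitor of the set; compound 2 lies nearest to it and compound 1 furthest from it, both at lower numbers that are beyond the scatter. For the measured compounds named here, the only single-point step among the measured compounds runs a 38-fold higher number from compound 1 to compound 3 (1.57 log units; beyond the scatter), a fluoro in place of hydrogen on an aromatic carbon, and it does not touch the acid end of the molecule.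

Compound 4, `O=C(O)Cc1ccc(C=C2CCN(C(=O)C(C3CCCCC3)C3CCCCC3)CC2)c(F)c1`, is not yet measured. It differs from compound 3 in one place: carboxymethyl in place of carboxy on an aromatic carbon. Going by the values given here, no measured step bears on this change; the one step that is known concerns a different position and a different group, and compounds 1 and 2 offer no pair that varies the acid group either. With nothing in the data pointing up or down, the expected step is none beyond the scatter, which is what no change at the digits printed from compound 3 to compound 4 (within the scatter) expresses as an estimate, though the range has to be wide. Compound 4 is therefore estimated at 3000 nM, between 700 nM and 13000 nM.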

Compound 4, half-maximal inhibitory concentration: 38 nM
Estimate against measurement, compound 4: 79-fold (1.90 log units) above; measured number below the stated range.
By their numbers in this assay, from the lowest: compound 4; then compound 1; then compound 2; then compound 3.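

In this assay the acid end of the molecule proves to be a sensitive position: carboxymethyl in place of carboxy, on the aromatic carbon para to a large group and meta to a fluoro group, gives a 79-fold lower number from compound 3 to compound 4 (1.90 log units; beyond the scatter) and so runs opposite in direction to the earlier 38-fold higher number from compound 1 to compound 3 (1.57 log units; beyond the scatter) that came with the fluoro group. The fluoro group therefore does not bring a higher number in every setting, for with carboxymethyl in place of carboxy the 4-(carboxymethyl)-2-fluorophenyl compound shows a 2.1-fold lower number from compound 1 to compound 4 (0.32 log units; beyond the scatter) and stands at the lowest number of the four. Nothing among the data given explains why one added carbon between the ring and the acid has an effect of this size or why it reverses the earlier loss.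

The compounds shown leave open whether carboxymethyl would bring a similar step on a ring without the fluoro group, or in a compound carrying the two phenyl groups of compound 2 in place of the two cyclohexyl groups. They also leave open how the number would respond to a longer chain such as carboxyethyl, or to a tetrazole or a sulfonic acid in place of the carboxylic acid.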